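Fluorophenoxy Analogue Weighed Against Three Assay Limits

The source may hold more compounds than are shown below. What is called first, only, known or untested is meant among the compounds shown, and "the series" means these compounds.

Of the compounds shown here, three sharing one core have been tested in a functional assay on COLO 205 cells (Homo sapiens) for inhibition, read by sulforhodamine B assay, with a stated time of 48 h; a lower number here means that less compound is tolerated, a higher number that more compound is tolerated. Compound 1 `Nc1cc(N)c2nc(-c3ccccc3)c(Oc3ccc(Cl)c(Cl)c3)nc2c1` gives < 100000 nM, which is a limit of the assay and not a number. Compound 2 `COc1ccc(CNc2nc3cc(N)cc(N)c3nc2-c2ccccc2)cc1OC` gives < 100000 nM, again a limit. Compound 3 `COc1ccc(Sc2nc3cc(N)cc(N)c3nc2-c2ccccc2)cc1` gives < 100000 nM, likewise a limit. Compound 3 thus stands with the other two at the limit of < 100000 nM in this assay, at which 3 of the 3 values shown sit, and no order among the three can be read from these values. Going by the values given here, the only step connecting measured compounds, a step that the two limits leave unreadable from compound 1 to compound 3, cannot be sized, since both of its ends are limits.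

Compound 4 `Nc1cc(N)c2nc(-c3ccccc3)c(Oc3ccc(F)cc3)nc2c1` has not yet been measured. It differs from compound 3 in one place: 4-fluorophenoxy in place of (4-methoxyphenyl)sulfanyl on an aromatic carbon. Among the compounds with values here, no measured step bears readably on this change, because the sole available step that the two limits leave unreadable from compound 1 to compound 3 has no readable size. What the data do offer is that every value obtained so far sits at the same limit. Compound 4 is therefore expected to fall where compound 3 falls. The expected step is a step that the limit leaves unreadable from compound 3 to compound 4, no larger than the scatter. The estimate for compound 4 in this assay is 50000 nM, with a range from 10000 nM to 100000 nM, and the likeliest outcome is that the assay again reports only a limit.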

Compound 4, concentration lethal to 50% of the cells: 66100 nM
The estimate for compound 4 lay 1.3-fold (0.12 log units) below the measured number, within the range that was stated.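

Neither the step from compound 1 to compound 4 nor the one from compound 3 to compound 4 can be read, because compound 1 and compound 3 each stand at a limit: the limit of < 100000 nM in this assay, at which 3 of the 4 values shown sit.

The compounds shown leave open how 4-fluorophenoxy, 3,4-dichlorophenoxy and (4-methoxyphenyl)sulfanyl on the shared core compare in this assay.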